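Swapping a Ring Hydrogen for Bromine in Sulfonyl Hydrazides

The compounds below may be only part of what the source reports. "The series", "measured", "known", "first", "only" and "open" are said of these compounds alone.

Measured compounds:
Compound 1 `CC(=O)Nc1ccc(S(=O)(=O)NNc2ccc(Br)cc2)cc1`: 85 nM
Compound 2 `CC(=O)Nc1ccc(S(=O)(=O)NNc2cc(F)cc(F)c2)cc1`: 2230 nM
Compound 3 `O=S(=O)(NNc1ccc(Br)cc1)c1ccccc1`: 128 nM

Of the compounds shown here, three have been tested in an assay on HeLa cells for inhibition of Indoleamine 2,3-dioxygenase 1 (Homo sapiens), read by spectrophotometry, with a stated time of 24 h; a higher number here means that more compound is needed for the effect, a lower number that less compound is needed. Compound 3 gives 128 nM, the second highest of the three numbers. Its nearest neighbour is compound 1, which in this assay gives 85 nM; the step of a 1.5-fold higher number from compound 1 to compound 3 (0.18 log units; within the scatter) lies within the scatter, so these two cannot be told apart. Compound 2, with 2230 nM, stands far away and well beyond the scatter.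

Compound 4 `O=S(=O)(NNc1ccc(Br)cc1)c1ccc(Br)cc1` has not been measured. It differs from compound 3 by bromo in place of hydrogen on an aromatic carbon. For the measured compounds named here, no measured pair tests exactly this change. Going by the values given here, the only step on record, from compound 1 to compound 3, also altered a group on the same six-membered aromatic ring of carbon only, and it stayed within the scatter. On that basis the step is expected to be small, roughly a 1.0-fold higher number from compound 3 to compound 4 (0.01 log units; within the scatter), in no clear direction. Compound 4 is therefore estimated at 130 nM, with a range from 50 nM to 350 nM.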

Compound 4, half-maximal effective concentration: 374 nM
Beside the measured number, compound 4's estimate is 2.9-fold (0.46 log units) below it; the whole stated range lies below it.
By their numbers in this assay, from the lowest: compounds 1 and 3 (each within the scatter of the next); then compound 4; then compound 2.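

Placing bromo at this position, para to a large group, gives a 2.9-fold higher number from compound 3 to compound 4 (0.47 log units; beyond the scatter) in this assay; the position therefore does respond to what sits on it, which the earlier step from acetamido to hydrogen could not show. Bromo also compares poorly with acetamido at the same place, with a 4.4-fold higher number from compound 1 to compound 4 (0.64 log units; beyond the scatter), so among these three groups bromo alone stands apart from the other two. Nothing available here explains this shift.

Among the compounds shown, only hydrogen, acetamido and bromo occupy this position, so it stays open whether the rise is particular to bromo or would appear with other groups. An amine, a methoxy group or a carboxylic acid at the same place would test how far the position tolerates change.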